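The source may report more compounds than this note shows. Statements on the series, on what has been measured and on what is new or still open speak of the compounds shown alone.

Measured so far in a functional assay on ileum (strain Hartley) for agonist activity at 5-hydroxytryptamine receptor 3A (Cavia porcellus); on this read-out higher numbers stand for higher potency (the scale is a negative logarithm) and lower numbers for lower potency:
- compound 1 `CN1CCN(c2nc3cc([N+](=O)[O-])ccc3o2)CC1` gives 6.1
- compound 2 `Cc1cc(Cl)c2oc(N3CCN(C)CC3)nc2c1` gives 6.22
- compound 3 `Cc1cccc2nc(N3CCN(C)CC3)oc12` gives 5.48

Among these three, compound 2 carries the highest number, but the gap to compound 1 lies within the usual scatter of repeated measurements, so the two cannot be told apart on these data. Compound 3 sits clearly lower than compound 2, by a margin beyond the scatter. All three share the same core bearing a methylpiperazine group and differ only in what decorates the aromatic ring of that core.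

Compound 4 `CCc1cc(C)cc2nc(N3CCN(C)CC3)oc12` is the next compound, not yet measured. It is derived from compound 2 by a single swap: ethyl in place of chloro on an aromatic carbon. The methyl group of compound 2 stays where it is, and the methylpiperazine is untouched.

Among the measured compounds shown here, no measured pair shows what such a swap does in this assay, so the expectation rests on the spread of the three measured numbers alone. A moderate downward step from compound 2 to compound 4 is estimated, a number 0.42 log units lower from compound 2 to compound 4 (beyond the scatter), though a result within the scatter of compound 2 would not surprise. Compound 4 is expected to give about 5.8 in this assay, with a plausible range from 5.2 to 6.4.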

Compound 4, negative logarithm of the half-maximal effective concentration: 6.46
For compound 4 the middle estimate is 0.66 log units below the measured one; measured number outside the range, above it.
By their numbers in this assay, from the lowest: compound 3; then compounds 1, 2 and 4 (each within the scatter of the next, the first and the last beyond it).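

In this assay, putting ethyl in place of chloro on this aromatic carbon, which is ortho to a fused ring and meta to a methyl group, gives a number 0.24 log units higher from compound 2 to compound 4 (within the scatter) and so leaves the two compounds indistinguishable on this read-out. Among the compounds shown here, this is the first direct look at this position, and for this one pair it shows that chlorine, a single heavy atom, can give way to a chain of two carbons with no change that stands clear of the scatter. Nothing available explains why these two groups give matching results, and a single pair cannot show whether that match would extend to other groups at this position.

The compounds shown leave open how far this position tolerates change, since they do not reveal what a longer chain such as propyl, an amine or a methoxy group would do on the same carbon. They also leave open what plain hydrogen would give there with the methyl group kept in place, which would show whether either chloro or ethyl contributes to the number at all.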